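This account rests on a few compounds, and the source may have more. Where it says the series, first, only, none or still open, it means among the compounds named here.

Measured compounds:
compound 1 `COc1c(C(=O)c2ccc3c(c2)C(C)(C)CCC3(C)C)ccc2cc(C(=O)O)ccc12` with 0%
compound 2 `CC1(C)CCC(C)(C)c2cc(C(O)c3ccc4cc(C(=O)O)ccc4c3)c(O)cc21` with 0%
compound 3 `Cc1cc2c(cc1C(O)c1ccc3cc(C(=O)O)ccc3c1)C(C)(C)CCC2(C)C` with 0%

The three measured compounds share a core, and all of them were tested in an assay on isolated protein with retinoic acid receptor alpha (Homo sapiens) as the target; a higher number here means a larger maximal response, a lower number a smaller maximal response. Compound 1 gives 0% in this assay, compound 2 gives 0%, and compound 3 gives 0%. Compound 3 therefore stands level with compounds 1 and 2; none of the three is set apart from the others at the digits shown. For the measured compounds named here, the one step that can be followed here is no change at the digits printed from compound 2 to compound 3 (within the scatter), a methyl in place of hydroxy on an aromatic carbon, and that step left the reading where it was.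

Compound 4 `CC1(C)CCC(C)(C)c2cc(C(O)c3ccc4cc(C(=O)O)ccc4c3)c(F)cc21` has not yet been measured in this assay. It differs from compound 3 in a single place: fluoro in place of methyl on an aromatic carbon. Going by the values given here, the only step that bears on this change is no change at the digits printed from compound 2 to compound 3 (within the scatter), which was flat, and the three measured compounds all sit at the same reading. On that basis the expected step is no change at the digits printed from compound 3 to compound 4 (within the scatter), that is, no movement beyond the scatter. Compound 4 is accordingly expected to give 0% in this assay, with a range from 0% to 12%.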

Compound 4, largest response reached (reported as maximum), in percent of the reference or control that the assay uses: 0%
Estimate against measurement, compound 4: no gap at the digits printed; the range from low to high includes it.
By their numbers in this assay, from the lowest: compounds 1, 2, 3 and 4 (each within the scatter of the next).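

At this position, on an aromatic carbon ortho to a large group, fluoro now joins hydroxy and methyl as a third group that can be compared in this assay. For the compounds shown here, replacing methyl with fluoro gives no change at the digits printed from compound 3 to compound 4 (within the scatter), and replacing hydroxy with fluoro gives no change at the digits printed from compound 2 to compound 4 (within the scatter), so compound 4 at 0% extends the single flat exchange seen earlier to three groups at this place. Nothing available explains why the reading is the same across these groups.

Since all the compounds shown share one reading, none provides a higher value against which the effect of this position could be judged, and they cannot show whether a group here can change the maximal response at all. On these data alone, whether an amine, a chloro group or a longer chain such as propyl at this position would give a reading beyond the scatter remains open.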